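A smaller amine on a shared core

This account rests on a few compounds, and the source may have more. Where it says the series, first, only, none or still open, it means among the compounds named here.

compound 1 `COc1cc2c(cc1OC)C(=O)/C(=C/c1cccc(O)c1)CO2` — compound 1 gives 21.9% in an assay on isolated protein for inhibition of Amine oxidase [flavin-containing] A (Homo sapiens), read by fluorescence, with a stated time of 30 min, tested at 20 uM; a higher number here means more inhibition at the concentration tested (going by the name of the read-out), a lower number less inhibition
compound 2 `COc1ccccc1CN(C)Cc1c(O)cccc1/C=C1\COc2cc(OC)c(OC)cc2C1=O` — compound 2 gives 9.8%

Compound 2 stands lowest of the two numbers in this assay; its nearest neighbour, compound 1, lies higher by a margin beyond the usual scatter. Going by the values given here, no two measured compounds differ in a single place, so no measured step guides the next change. Compound 3 `CCN(Cc1ccccc1)Cc1c(O)cccc1/C=C1\COc2cc(OC)c(OC)cc2C1=O` differs from compound 2 in one respect: benzyl(ethyl)amino in place of (2-methoxybenzyl)(methyl)amino on a saturated chain carbon bound to an aromatic carbon. Among the compounds with values here, with only two measured values at hand, a step in this assay of no size beyond the scatter is expected, in no set direction. This expected step amounts to a number 2.2 percentage points higher from compound 2 to compound 3 (within the scatter). Compound 3 is therefore estimated at 12%, within 2% to 25%.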

Compound 3, a percentage reported as inhibition, at one concentration (the size of the read-out at that concentration, not a potency): 9.8%
Estimate against measurement, compound 3: 2.2 percentage points above, within the range that was stated.
By their numbers in this assay, from the lowest: compounds 2 and 3 (each within the scatter of the next); then compound 1.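

In this assay the change to benzyl(ethyl)amino from (2-methoxybenzyl)(methyl)amino on a saturated chain carbon bound to an aromatic carbon gives no change at the digits printed from compound 2 to compound 3 (within the scatter) and so does not separate these two amines. Adding (benzyl(ethyl)amino)methyl in place of hydrogen on an aromatic carbon gives a number 12.1 percentage points lower from compound 1 to compound 3 (beyond the scatter) on the shared core. No supporting measurement bears on the reason for either result.

Still open, as far as these compounds go, is whether a dimethylamino or morpholine group in this place would read differently from these two benzyl-bearing amines.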